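Dropping a Fluorine: Expected Solubility of Compound 4

This account rests on a few compounds, and the source may have more. Where it says the series, first, only, none or still open, it means among the compounds named here.

Measured compounds and their solubility:
compound 1, `Fc1ccc(Cc2ccc3c(NCCCNCc4ccco4)ccnc3c2)cc1`: 4200 nM
compound 2, `COc1cccc(CNCCCNc2ccnc3cc(Cc4ccc(F)cc4)ccc23)c1O`: 4200 nM
compound 3, `COc1ccc(F)cc1CNCCCNc1ccnc2cc(Cc3ccc(F)cc3)ccc12`: 4200 nM

In a physicochemical assay for solubility, with a stated time of 18 h, at pH 7.4 (a higher number here means a more soluble compound, a lower number a less soluble compound), compound 2 gives 4200 nM, level with compound 1 and compound 3 at the digits shown. Compound 4, `COc1cccc(CNCCCNc2ccnc3cc(Cc4ccccc4)ccc23)c1O`, has not been measured. It differs from compound 2 in one place: hydrogen in place of fluoro on an aromatic carbon. The three measured steps all change the group on the saturated chain carbon bound to an amine nitrogen: no change at the digits printed from compound 1 to compound 2 (within the scatter), no change at the digits printed from compound 1 to compound 3 (within the scatter) and no change at the digits printed from compound 2 to compound 3 (within the scatter). For the measured compounds named here, none of them touches the 4-fluorophenyl, so no measured step bears directly on the change to compound 4. What the data do show is that three different groups elsewhere in the molecule left solubility unchanged within the scatter, and the change from 4-fluorophenyl to phenyl removes only a single fluorine. No step beyond the scatter is therefore expected. Compound 4 is estimated at 4200 nM, between 2000 nM and 8500 nM. For compound 4 the expected step is no change at the digits printed from compound 2 to compound 4 (within the scatter), within the scatter.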

Compound 4, solubility: 4200 nM
The estimate for compound 4 equals the measured number at the digits printed; measured number inside the range.
By their numbers in this assay, from the lowest: compounds 1, 2, 3 and 4 (each within the scatter of the next).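

For the compounds shown here, this is the first measured step at the 4-fluorophenyl rather than at the group on the chain: the step reads no change at the digits printed from compound 2 to compound 4 (within the scatter) in this assay when hydrogen replaces fluoro on an aromatic carbon para to a large group. With 2-hydroxy-3-methoxyphenyl held in place on the chain, the 4-fluorobenzyl and benzyl compounds therefore read level, and this end of the molecule now has a measured step of its own. Nothing offered here explains why these two compounds read level.

The compounds shown leave open whether a chlorine, a methoxy, an amine or a carboxylic acid at this same place would also read level with fluoro and hydrogen. From the compounds shown here alone, whether removing the fluorine gives the same result with furan-2-yl or 5-fluoro-2-methoxyphenyl on the chain also remains open.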